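The compounds below may be only part of what the source reports. "The series", "measured", "known", "first", "only" and "open" are said of these compounds alone.

Measured compounds in an ADME assay for permeability, using PAMPA, with a stated time of 4 h; a higher number here means that the compound crosses the layer faster, a lower number that the compound crosses the layer more slowly:
- compound 1, `Cn1c(COc2cccc(C(=O)O)c2)nc2ccc(Oc3ccc(Cl)c(F)c3)nc21`: 25.6 10^-6 cm/s
- compound 2, `Cc1ccc(Oc2ccc3nc(COc4cccc(C(=O)O)c4)n(C)c3n2)cc1F`: 14.8 10^-6 cm/s
- compound 3, `Cn1c(COc2cccc(C(=O)O)c2)nc2ccc(Oc3cccc(Cl)n3)cc21`: 7.6 10^-6 cm/s

Compound 3 sits within the usual scatter of compound 2 in this assay, while compound 1 lies clearly higher, beyond the scatter of compound 3. The one single-point step recorded among these compounds, a 1.7-fold lower number from compound 1 to compound 2 (0.24 log units; within the scatter), shows that exchanging one aromatic substituent left the reading essentially unchanged.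

Compound 4, `Cn1c(COc2cccc(C(=O)O)c2)nc2ccc(Oc3ccc(F)cn3)cc21`, differs from compound 3 by 5-fluoropyridin-2-yl in place of 6-chloropyridin-2-yl on an oxygen on an aromatic ring. Among the measured compounds shown here, no measured pair carries exactly this exchange; the step from compound 1 to compound 2 is the only comparison of two halogen-bearing aryl ethers on the shared core, and it stayed within the scatter. On that basis a step of similar size, not beyond the scatter, is expected for the change from compound 3 to compound 4, that is a 1.2-fold lower number from compound 3 to compound 4 (0.07 log units; within the scatter), with no clear direction. Compound 4 is therefore estimated at 6.5 10^-6 cm/s in this assay, with a likely range from 3 10^-6 cm/s to 14 10^-6 cm/s.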

Compound 4, apparent permeability: 4.7 10^-6 cm/s
The estimate for compound 4 lay 1.4-fold (0.14 log units) above the measured number; low and high end bracket the measured number.
By their numbers in this assay, from the lowest: compounds 4, 3, 2 and 1 (each within the scatter of the next, the first and the last beyond it).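

In this assay, the exchange of 6-chloropyridin-2-yl for 5-fluoropyridin-2-yl on an oxygen on an aromatic ring gives a 1.6-fold lower number from compound 3 to compound 4 (0.21 log units; within the scatter), so the two pyridinyl ethers cannot be told apart in this read-out. This is the first step shown in which the group on that oxygen is a pyridine on both sides, and the group that enters matches the one that leaves in its count of heavy atoms, donors and acceptors. The step changes the halogen and its place on the ring together, and no measurement shown offers an explanation for the reading.

The compounds shown leave open whether the identity of the halogen or its place on the ring has any separate effect on the reading. They also leave open how the reading would respond to an amine or a nitrile on the pyridine ring in place of the halogen.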